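Taking the Chloro Off Compound 2

The compounds below may be only part of what the source reports. "The series", "measured", "known", "first", "only" and "open" are said of these compounds alone.

Three related compounds built on a shared core have been measured so far. In a functional assay on MCF7 cells (Homo sapiens) for inhibition, read by sulforhodamine B assay, with a stated time of 48 h, tested at 10 uM (on this read-out lower numbers stand for less inhibition of growth and higher numbers for more inhibition of growth at the one concentration tested), compound 1 (`COc1ccc(-c2nc3sc(-c4ccccc4)cn3n2)cc1`) gives 74%, and compound 3 (`COc1ccc(-c2nc3sc(-c4ccc(Cl)cc4)cn3n2)cc1`) gives 51.1%. Compound 2 (`Clc1ccc(-c2cn3nc(-c4ccccc4)nc3s2)cc1`) gives 35%, the lowest of the three, and its gaps to both others lie beyond the scatter.

The next compound to be measured is compound 4 (`c1ccc(-c2nc3sc(-c4ccccc4)cn3n2)cc1`). It differs from compound 2 by a single swap, hydrogen in place of chloro on an aromatic carbon.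

Among the compounds with values here, two measured steps bear on this swap. The opposite change, chloro in place of hydrogen on an aromatic carbon, gave a number 22.9 percentage points lower from compound 1 to compound 3 (beyond the scatter). Run backwards, that step points to a modest rise on losing the chloro. The other change, methoxy in place of hydrogen on an aromatic carbon, gave a number 16.1 percentage points higher from compound 2 to compound 3 (beyond the scatter). Taking a step of that size down from the value of compound 1, 74%, lands in about the same place as adding the first step to compound 2.

A rise beyond the scatter is therefore expected in this assay. The estimated step is a number 23 percentage points higher from compound 2 to compound 4 (beyond the scatter). Compound 4 is expected to give 58%, with an estimated range of 43% to 73%.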

Compound 4, percent growth inhibition at one concentration: 61%
Compound 4: middle estimate off by 3 percentage points, on the low side, within the range that was stated.
By their numbers in this assay, from the lowest: compound 2; then compounds 3 and 4 (each within the scatter of the next); then compound 1.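

Compound 4 completes a set of four compounds in which chloro and methoxy are each present or absent, so each change can now be read on two cores. In this assay, hydrogen in place of chloro on the six-membered aromatic ring gives a number 26 percentage points higher from compound 2 to compound 4 (beyond the scatter), which shows that the drop linked to chloro does not depend on methoxy being present: the same change on two cores in this assay, a number 22.9 percentage points lower (beyond the scatter) from compound 1 to compound 3 and a number 26 percentage points lower (beyond the scatter) from compound 4 to compound 2, 3.1 percentage points apart, within the scatter of two such steps The methoxy change can now be read on two cores as well, with hydrogen in its place giving a number 13 percentage points lower from compound 1 to compound 4 (beyond the scatter), and its size also holds whether or not chloro is present: the same change on two cores in this assay, a number 16.1 percentage points higher (beyond the scatter) from compound 2 to compound 3 and a number 13 percentage points higher (beyond the scatter) from compound 4 to compound 1, 3.1 percentage points apart, within the scatter of two such steps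

The compounds shown leave open whether the drop is particular to chloro or would also follow from another group at this place, such as fluoro, methyl or an amine. They also cannot tell how a carboxylic acid or a longer chain would fare there, or whether these steps would hold on a core that differs further from these four.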